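The source may hold more compounds than are shown below. What is called first, only, known or untested is meant among the compounds shown, and "the series" means these compounds.

The series shares one core and varies the group on the phenyl that hangs from the piperazine. Compound 1 `CCCn1c(=O)[nH]c2nc(-c3ccc(S(=O)(=O)N4CCN(c5ccccc5C)CC4)cc3)[nH]c2c1=O` carries a methyl there and gives 25% in an assay on CHO cells for displacement of a labelled ligand from adenosine receptor A3 (Homo sapiens), read by scintillation counting, with a stated time of 45 min, tested at 1 uM, in the presence of a further agent that is not named here; on this read-out higher numbers stand for more inhibition at the one concentration tested (going by the name of the read-out) and lower numbers for less inhibition. Compound 2 `CCCn1c(=O)[nH]c2nc(-c3ccc(S(=O)(=O)N4CCN(c5ccccc5F)CC4)cc3)[nH]c2c1=O` carries a fluoro instead and gives 9%. Compound 3 `CCCn1c(=O)[nH]c2nc(-c3ccc(S(=O)(=O)N4CCN(c5ccccc5)CC4)cc3)[nH]c2c1=O` carries hydrogen on that phenyl and gives 27%, the highest number of the three, though its gap to compound 1 lies within the scatter and only its gap to compound 2 lies beyond it: a number 2 percentage points higher from compound 1 to compound 3 (within the scatter), a number 18 percentage points higher from compound 2 to compound 3 (beyond the scatter), while a number 16 percentage points lower from compound 1 to compound 2 (beyond the scatter).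

Compound 4 `CCCn1c(=O)[nH]c2nc(-c3ccc(S(=O)(=O)N4CCN(c5ccc(I)cc5)CC4)cc3)[nH]c2c1=O` differs from compound 3 in one place: iodo in place of hydrogen on an aromatic carbon. Among the measured compounds shown here, no measured step introduces iodo, and the two exchanges that do touch the phenyl read phenyl to methylphenyl and phenyl to fluorophenyl, each of modest size or within the scatter. Those steps therefore give only a loose guide. The writer expects compound 4 to stay close to compound 3, with a step of a number 5 percentage points lower from compound 3 to compound 4 (within the scatter) that need not exceed the scatter, and estimates for compound 4 a value of 22%, ranging from 5% to 40%.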

Compound 4, a percentage reported as inhibition, at one concentration (the size of the read-out at that concentration, not a potency): 36%
The estimate for compound 4 lay 14 percentage points below the measured number, within the range that was stated.
By their numbers in this assay, from the lowest: compound 2; then compounds 1, 3 and 4 (each within the scatter of the next, the first and the last beyond it).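

With iodo in place of hydrogen, the position para to a large group on the phenyl accepts a single large halogen atom without a step that exceeds the scatter in this assay: a number 9 percentage points higher from compound 3 to compound 4 (within the scatter). The earlier compounds shown here carried their groups only as 2-methylphenyl and 2-fluorophenyl, and the 4-iodophenyl now stands clear of both, with a number 11 percentage points higher from compound 1 to compound 4 (beyond the scatter) and a number 27 percentage points higher from compound 2 to compound 4 (beyond the scatter), whereas the unsubstituted phenyl of compound 3 stood clear of the 2-fluorophenyl alone. Nothing among the available data speaks to why the numbers fall this way.

Going by these compounds, it remains open whether the iodo group or its place accounts for these gaps, as each of the two steps changes both at once, and a 4-fluorophenyl, a 4-methylphenyl or a 2-iodophenyl would be needed to pull the two apart. Also open, on these data alone, is how an amine, a carboxylic acid or a longer chain would read at the same place on the phenyl, and whether any group there would carry the inhibition clearly beyond that of the plain phenyl in compound 3.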